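Oxadiazolylpiperazine Amide in Place of Carbamoylazetidine Amide

A few compounds are considered here, and "the series" means these few. Any claim that something is new, unique, unknown or untested is made for them only; others in the source may bear on it.

Compound 2 `CCN(CC)S(=O)(=O)c1ccc(S(=O)(=O)N2CCC[C@@H](C(=O)NC3CN(C(=O)NC(C)(C)C)C3)C2)cc1` bears a (1-((tert-butyl)carbamoyl)azetidin-3-yl)amino group on the carbonyl carbon. In a functional assay on MIA PaCa-2 cells (Homo sapiens) for inhibition, read by MTT assay, with a stated time of 3 days (on this read-out lower numbers stand for stronger inhibition and higher numbers for weaker inhibition), compound 2 gives > 10000 nM, which is a limit of the assay and not a number. Compound 1 `CCN(CC)S(=O)(=O)c1ccc(S(=O)(=O)N2CCC[C@@H](C(=O)N3CCN(c4nc(C(F)(F)F)no4)CC3)C2)cc1` was measured in this assay as well, and compound 1 gives > 10000 nM, again a limit rather than a number. Going by the values given here, both values sit at the limit of > 10000 nM in this assay, at which 2 of the 2 values shown sit, so compound 2 stands level with the only other value shown and no number ranks it. Compound 3 `CCN(CC)S(=O)(=O)c1ccc(S(=O)(=O)N2CCC[C@@H](C(=O)N3CCN(c4nc(C)no4)CC3)C2)cc1` has not yet been measured; it differs from compound 2 by 4-(3-methyl-1,2,4-oxadiazol-5-yl)piperazin-1-yl in place of (1-((tert-butyl)carbamoyl)azetidin-3-yl)amino on a carbonyl carbon. Among the compounds with values here, no step between measured compounds is available to size this change, and compound 1 already carries a closely related oxadiazolylpiperazine amide. Compound 3 is therefore expected to show a step that the limit leaves unreadable from compound 2 to compound 3 that is none beyond the scatter. The estimate for compound 3 is 20000 nM, expected within 5000 nM to 100000 nM, most likely again reported as a limit.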

Compound 3, half-maximal inhibitory concentration: > 10000 nM
Compound 3 gave a limit, no number (the forecaster's own chance of this, stated with the estimate: 85%); the middle value lies beyond the limit too.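

Compound 3 stands with compound 1 and compound 2 at a limit in this assay, so neither step to compound 3 can be read: the limit of > 10000 nM in this assay, at which 3 of the 3 values shown sit.

The compounds shown leave open what number any of the three would give, and whether either change alters the read-out at all.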